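The compounds below may be only part of what the source reports. "The series", "measured", "known", "first", "only" and "open" are said of these compounds alone.

Compound 1 `COc1ccc(-c2oc3c(OC)c(OC)cc(OCCCC(=O)NCc4ccccn4)c3c(=O)c2O)cc1`: in a functional assay on MCF7 cells (Homo sapiens) for antiproliferative activity, read by sulforhodamine B assay, with a stated time of 48 h (a higher number here means a weaker inhibitor, a lower number a stronger inhibitor), compound 1 gives > 40000 nM, which is a limit of the assay and not a number.
Compound 2 `COc1ccc(-c2oc3c(OC)c(OC)cc(OCCCC(=O)N4CCN(C)CC4)c3c(=O)c2O)cc1`: in this assay compound 2 gives > 40000 nM, again a limit rather than a number.
Compound 3 `COc1ccc(-c2oc3c(OC)c(OC)cc(OCCCCC(=O)NCc4ccccn4)c3c(=O)c2O)cc1`: in this assay compound 3 gives > 40000 nM, also a limit.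

All three measured compounds share one core and differ only in the chain that hangs from the oxygen on the aromatic ring and in the amide at its end. From compound 1 to compound 2 the change is 4-methylpiperazin-1-yl in place of ((pyridin-2-yl)methyl)amino on a carbonyl carbon. The step this made is a step that the two limits leave unreadable from compound 1 to compound 2. The two cores differ by (((pyridin-2-yl)methyl)carbamoyl)methyl in place of ((pyridin-2-yl)methyl)carbamoyl on a saturated chain carbon, three bonds along the chain from an oxygen on an aromatic ring, and the step from compound 1 to compound 3 reads a step that the two limits leave unreadable from compound 1 to compound 3, while a step that the two limits leave unreadable from compound 2 to compound 3 is equally unreadable. All three values sit at the limit of > 40000 nM in this assay, at which 3 of the 3 values shown sit, so none of these steps can be given a size.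

The unmeasured compound 4 `COc1ccc(-c2oc3c(OC)c(OC)cc(OCCCCC(=O)N4CCN(C)CC4)c3c(=O)c2O)cc1` carries the same change as compound 1 to compound 2, now on the longer chain: 4-methylpiperazin-1-yl in place of ((pyridin-2-yl)methyl)amino on a carbonyl carbon. The place is worded the same for both pairs, so this is the same change on a different core. Compound 4 is expected to show a step that the limit leaves unreadable from compound 3 to compound 4 in this assay, an expectation resting on compound 3 with > 40000 nM and on compound 2 with > 40000 nM both sitting at the limit. Compound 4 is therefore estimated at 60000 nM, in the range 25000 nM to 200000 nM, most likely again reported only as a limit.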

Compound 4, half-maximal inhibitory concentration: > 40000 nM
Compound 4: a limit, no number; the forecaster's own chance of this, stated with the estimate: 85%; the middle value is on the limit's open side.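

In this assay compound 4 gives > 40000 nM, a limit of the assay and not a number. Its steps to compound 1, compound 2 and compound 3 therefore cannot be read, because all four compounds share one limit: the limit of > 40000 nM in this assay, at which 4 of the 4 values shown sit.

The compounds shown leave open how these two chain lengths and two amides rank against one another, and whether any of them has a measurable effect at all.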